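Propargyl on the Ring Amine: An Expected Weak Binder

The compounds below may be only part of what the source reports. "The series", "measured", "known", "first", "only" and "open" are said of these compounds alone.

Compound 1 `CCN1CCC(N2CCN(c3ccccc3)CC2)C(O)C1` bears an ethyl group on its ring nitrogen. In an assay on PC-12 cells for displacement of a labelled ligand from vesicular acetylcholine transporter (Homo sapiens) (a higher number here means a weaker inhibitor, a lower number a stronger inhibitor), compound 1 returns only a limit, > 1000 nM, and no number. Compound 2 `OC1CCNCC1N1CCN(c2ccccc2)CC1` leaves that ring amine nitrogen bare. In this assay compound 2 likewise returns only a limit, > 100 nM. Compound 2 therefore stands at the limit of > 100 nM in this assay, at which 1 of the 2 values shown sits, while the other reading in the set sits at the limit of > 1000 nM in this assay, at which 1 of the 2 values shown sits; neither gives a number to rank.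

Compound 3 `C#CCN1CCC(O)C(N2CCN(c3ccccc3)CC2)C1` differs from compound 2 by propargyl in place of hydrogen on an amine nitrogen in a ring. Going by the values given here, no measured pair isolates a group on this nitrogen, since compound 1 also differs from compound 2 in where the hydroxy and the large group sit. With both known readings at limits, the step is expected to be small or none beyond the scatter, and the estimated step that the limit leaves unreadable from compound 2 to compound 3 reflects that. Compound 3 is expected to give about 1500 nM, within 300 nM to 8000 nM.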

Compound 3, half-maximal inhibitory concentration: > 100 nM
Compound 3: no number, only a limit (the forecaster's own chance of this, stated with the estimate: 70%); the middle value is on the limit's open side.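

Going by these compounds alone, compound 3, like compound 2, returns only a limit in this assay, so no step from compound 2 to compound 3 can be read. The compounds shown leave open how much propargyl on the ring nitrogen changes binding, if it changes it at all.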